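Hydroxy in place of trifluoromethyl on two cores

The source may report more compounds than this note shows. Statements on the series, on what has been measured and on what is new or still open speak of the compounds shown alone.

Values in an ADME assay on HaCaT cells (Homo sapiens) for antiproliferative activity, read by MTT assay, with a stated time of 48 h; a lower number here means a stronger inhibitor, a higher number a weaker inhibitor:
compound 1 `O=C(/C=C\Nc1ccc(C(F)(F)F)cc1)c1cn(-c2ccccc2)nc1-c1ccc(Cl)cc1` gives > 50000 nM, a limit of the assay.
compound 2 `O=C(/C=C\Nc1ccc(O)cc1)c1cn(-c2ccccc2)nc1-c1ccc(Cl)cc1` gives 22600 nM.
compound 3 `COc1cc(-c2nn(-c3ccccc3)cc2C(=O)/C=C\Nc2ccc(C(F)(F)F)cc2)cc(OC)c1OC` gives > 50000 nM, a limit of the assay.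

Compound 2 differs from compound 1 by hydroxy in place of trifluoromethyl on an aromatic carbon, and the change gave an at least 2.2-fold lower number from compound 1 to compound 2 (0.34 log units; beyond the scatter). Compound 3 differs from compound 1 by 3,4,5-trimethoxyphenyl in place of 4-chlorophenyl on an aromatic carbon; here a step that the two limits leave unreadable from compound 1 to compound 3, since two of the three values sit at the limit of > 50000 nM in this assay, at which 2 of the 3 values shown sit.

Compound 4 `COc1cc(-c2nn(-c3ccccc3)cc2C(=O)/C=C\Nc2ccc(O)cc2)cc(OC)c1OC` is not yet measured. It differs from compound 3 by hydroxy in place of trifluoromethyl on an aromatic carbon, the same change as from compound 1 to compound 2, at the same place. Compound 4 is expected at 40000 nM, between 15000 nM and 100000 nM, which means an expected at least 1.2-fold lower number from compound 3 to compound 4 (0.09 log units; that floor lies within the scatter). This rests on an at least 2.2-fold lower number from compound 1 to compound 2 (0.34 log units; beyond the scatter) and on compound 3 standing at the limit of > 50000 nM in this assay, at which 2 of the 3 values shown sit, so only a limit may again be returned.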

Compound 4, half-maximal inhibitory concentration: 17600 nM
Beside the measured number, compound 4's estimate is 2.3-fold (0.36 log units) above it; the range from low to high includes it.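

On the second core, hydroxy in place of trifluoromethyl again lowers the number in this assay, giving an at least 2.8-fold lower number from compound 3 to compound 4 (0.45 log units; beyond the scatter), so the change runs the same way on both cores shown. Set side by side, the two steps read: the same change on two cores in this assay, an at least 2.2-fold lower number (0.34 log units; beyond the scatter) from compound 1 to compound 2 and an at least 2.8-fold lower number (0.45 log units; beyond the scatter) from compound 3 to compound 4; the limit leaves it open whether they differ. Compound 1 and compound 3 both stand at a limit of the assay, which makes each step a floor, leaves the step between those two compounds unreadable, and gives no rule for further cores: the limit of > 50000 nM in this assay, at which 2 of the 4 values shown sit.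

Open, on these data alone, is whether an amine or a carboxylic acid in the place of hydroxy would lower the number as well. Also open, as far as these compounds go, is whether the change carries over to a core with a longer chain in place of 4-chlorophenyl or 3,4,5-trimethoxyphenyl.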